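Amide aryl swap on the shared core: 4-cyanophenyl for 2-methylphenyl

This account rests on a few compounds, and the source may have more. Where it says the series, first, only, none or still open, it means among the compounds named here.

Two compounds of the series have numbers in a functional assay on GTL 16 cells for antiproliferative activity against GTL 16 cell line (Homo sapiens), read by CCK-8 assay, with a stated time of 72 h; a lower number here means a stronger inhibitor, a higher number a weaker inhibitor. Compound 1 `O=C(Nc1cccc(-c2oc3cc(-c4ccc(F)cc4)ccc3c(=O)c2O)c1)c1ccccc1F` gives 17400 nM. Compound 2 `Cc1ccccc1C(=O)Nc1cccc(-c2oc3cc(-c4ccc(F)cc4)ccc3c(=O)c2O)c1` gives 24800 nM. For the measured compounds named here, compound 2 stands highest of the two, but its only neighbour is compound 1 and the gap is small: a 1.4-fold higher number from compound 1 to compound 2 (0.15 log units; within the scatter). That single step is a methyl in place of fluoro on an aromatic carbon of the amide aryl group, and it did not move the read-out beyond the scatter.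

Compound 3 `N#Cc1ccc(C(=O)Nc2cccc(-c3oc4cc(-c5ccc(F)cc5)ccc4c(=O)c3O)c2)cc1` is not yet measured. Its difference from compound 2 is 4-cyanophenyl in place of 2-methylphenyl on a carbonyl carbon. Going by the values given here, the one measured step touches the same amide aryl group, but it exchanges a small substituent at one position, whereas the step to compound 3 replaces the whole group, so it bears only loosely on the question. With nothing in the series pointing either way, the expectation for compound 3 in this assay is a number of the same order as that of compound 2, with the step of a 1.2-fold lower number from compound 2 to compound 3 (0.07 log units; within the scatter) expected to stay within the scatter. The estimate for compound 3 is 21000 nM, with a range from 7000 nM to 63000 nM.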

Compound 3, half-maximal inhibitory concentration: 31800 nM
For compound 3 the middle estimate is 1.5-fold (0.18 log units) below the measured one, and the stated range covers the measured number.
By their numbers in this assay, from the lowest: compounds 1, 2 and 3 (each within the scatter of the next).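

In this assay the earlier pair exchanged only a small substituent on the aryl group of the amide, while here the whole group on the carbonyl carbon changes, and 4-cyanophenyl in place of 2-methylphenyl gives a 1.3-fold higher number from compound 2 to compound 3 (0.11 log units; within the scatter) while 4-cyanophenyl in place of 2-fluorophenyl gives a 1.8-fold higher number from compound 1 to compound 3 (0.26 log units; within the scatter) and neither step leaves the scatter. Among these three compounds, then, the read-out does not separate the amide aryl groups, even though the entering 4-cyanophenyl carries a nitrile with a hydrogen-bond acceptor that is absent from 2-methylphenyl. No measurement in hand speaks to why the three numbers stay so close.

Still open, from the compounds shown here alone, is whether any group on the carbonyl carbon can move the number beyond the scatter in this assay at all: an aryl group carrying an amine or a carboxylic acid, or a longer alkyl chain in place of the aryl ring, would test this. Also open, going by these compounds, is whether changes elsewhere on the shared core matter more than changes at this position.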